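The source may report more compounds than this note shows. Statements on the series, on what has been measured and on what is new or still open speak of the compounds shown alone.

Compound 1 `CCN(CC)S(=O)(=O)c1ccc(S(=O)(=O)N2CCC[C@@H](C(=O)N[C@H]3CC[C@H](OC)CC3)C2)cc1`: 2000 nM
Compound 2 `CCC(CC)S(=O)(=O)c1ccc(S(=O)(=O)N2CCC[C@@H](C(=O)N3CCC(F)(F)CC3)C2)cc1`: 40 nM
Compound 3 `CCN(CC)S(=O)(=O)c1ccc(S(=O)(=O)N2CCC[C@@H](C(=O)NC3CCOCC3)C2)cc1`: 8570 nM

All three were tested in a functional assay on BXPC-3 cells (Homo sapiens) for inhibition, read by MTT assay, with a stated time of 7 days; a higher number here means a weaker inhibitor, a lower number a stronger inhibitor. Compound 2 gives the lowest number of the three; compound 1 stands well above it, and compound 3 higher still. Within the data shown here, the only pair differing in one place is a 4.3-fold higher number from compound 1 to compound 3 (0.63 log units; beyond the scatter), which alters the group on an amide-type nitrogen, not the group on the sulfonyl sulfur. Compound 4 `O=C([C@@H]1CCCN(S(=O)(=O)c2ccc(S(=O)(=O)C3CC3)cc2)C1)N1CCC(F)(F)CC1` differs from compound 2 by cyclopropyl in place of pentan-3-yl on a sulfonyl sulfur. No measured step touches that sulfonyl position, so nothing shown tells how large this change should be; a modest weakening is assumed as a cautious guess. Compound 4 is therefore expected to give 100 nM (range 25 nM to 400 nM) in this assay. That amounts to an expected step of a 2.5-fold higher number from compound 2 to compound 4 (0.40 log units; beyond the scatter).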

Compound 4, half-maximal inhibitory concentration: 129 nM
The estimate for compound 4 lay 1.3-fold (0.11 log units) below the measured number; the measured number falls inside the stated range.
By their numbers in this assay, from the lowest: compound 2; then compound 4; then compound 1; then compound 3.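

In this assay the group on the sulfonyl sulfur now has a measured step of its own: cyclopropyl in place of pentan-3-yl gives a 3.2-fold higher number from compound 2 to compound 4 (0.51 log units; beyond the scatter) and so shows that this position affects the number. The step is modest and beyond the scatter, so the open five-carbon group can give way to a three-carbon ring with only a moderate weakening. No measurement here explains the shift.

As far as these compounds go, whether the ring or the smaller carbon count matters remains open. Cyclopentyl, which keeps five carbons but in a ring, would help separate the two.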